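Acetyl position on the aniline of a shared core

A few compounds are considered here, and "the series" means these few. Any claim that something is new, unique, unknown or untested is made for them only; others in the source may bear on it.

Three compounds share one core. Compound 1 `CCOC(=O)c1ccc(Nc2ccnc(SCC(=O)c3ccc([N+](=O)[O-])cc3)n2)cc1` gives 21% in a functional assay on A549 cells (Homo sapiens) for inhibition, read by sulforhodamine B assay, with a stated time of 48 h, tested at 10 uM; a lower number here means less inhibition of growth, a higher number more inhibition of growth at the concentration tested. Compound 2 `O=C(O)c1ccc(Nc2ccnc(SCC(=O)c3ccc(C(F)(F)F)cc3)n2)cc1` gives 10% in this assay, and compound 3 `CC(=O)c1cccc(Nc2ccnc(SCC(=O)c3ccc(-c4ccccc4)cc3)n2)c1` gives 14%. Compound 3 sits in the middle of the three numbers; its gap to compound 2 and its gap to compound 1 both lie within the usual scatter, so no ordering among the three is claimed. Among the measured compounds shown here, no two measured compounds differ in a single place, so no measured step is at hand. Compound 4 `CC(=O)c1ccc(Nc2ccnc(SCC(=O)c3ccc(-c4ccccc4)cc3)n2)cc1` differs from compound 3 by 4-acetylphenyl in place of 3-acetylphenyl on a nitrogen on an aromatic ring. For the measured compounds named here, with no measured step to lean on, the step expected in this assay is a number 1 percentage points higher from compound 3 to compound 4 (within the scatter), none beyond the scatter. Compound 4 is estimated at 15%, within a range from 4% to 28%.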

Compound 4, percent growth inhibition at one concentration: 20%
Compound 4: middle estimate off by 5 percentage points, on the low side, within the range that was stated.
By their numbers in this assay, from the lowest: compounds 2, 3, 4 and 1 (each within the scatter of the next, the first and the last beyond it).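

In this assay, 4-acetylphenyl in place of 3-acetylphenyl on a nitrogen on an aromatic ring gives a number 6 percentage points higher from compound 3 to compound 4 (within the scatter). Among the compounds shown here, this is the first single-place comparison, and it shows that these two acetylphenyl isomers cannot be told apart at this position. No available evidence bears on this result. Still open, on these data alone, is whether an amine or a nitrile in place of the acetyl group would differ from compound 4 beyond the scatter. Also open, as far as these compounds go, is whether the same isomer swap reads alike with another group on the ketone's aromatic ring.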